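Methyl to trifluoromethyl on a shared core

The compounds below may be only part of what the source reports. "The series", "measured", "known", "first", "only" and "open" are said of these compounds alone.

Compound 1 (`Clc1ccc2[nH]c(-c3cn(-c4ccccc4)nc3-c3ccccc3)nc2c1`) gives > 50000 nM (a limit)
Compound 2 (`Cc1ccc2[nH]c(-c3cn(-c4ccccc4)nc3-c3ccccc3)nc2c1`) gives > 50000 nM (a limit)

In an ADME assay on HaCaT cells (Homo sapiens) for cytotoxicity, read by MTT assay, with a stated time of 48 h (a lower number here means a stronger inhibitor, a higher number a weaker inhibitor), compound 2 gives > 50000 nM and that is a limit of the assay, not a number. Compound 1 gives > 50000 nM and that is also a limit. The evidence so far comes to this (the limit of > 50000 nM in this assay, at which 2 of the 2 values shown sit) and nothing more.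

The next compound, compound 3 (`FC(F)(F)c1ccc2[nH]c(-c3cn(-c4ccccc4)nc3-c3ccccc3)nc2c1`), carries trifluoromethyl in place of methyl on an aromatic carbon. For the measured compounds named here, the only measured step that bears on this change is a step that the two limits leave unreadable from compound 1 to compound 2 and it offers no size to carry over. The data therefore give no reason to expect a step beyond the usual scatter in this assay and favour no direction. The expected change is a number no higher from compound 2 to compound 3 (the limit leaves the size open) and it is only an estimate. Compound 3 may well report only a limit too. For compound 3 the estimate is 50000 nM with 20000 nM to 100000 nM as the expected range.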

Compound 3, half-maximal inhibitory concentration: 37200 nM
Compound 3: middle estimate off by 1.3-fold (0.13 log units), on the high side; measured number inside the range.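

For the compounds shown here, with trifluoromethyl at this place on the aromatic ring, compound 3 gives 37200 nM in this assay, the first value in this set that is a number and not a limit. Trifluoromethyl in place of methyl gives an at least 1.3-fold lower number from compound 2 to compound 3 (0.12 log units; that floor lies within the scatter), and trifluoromethyl in place of chloro gives an at least 1.3-fold lower number from compound 1 to compound 3 (0.12 log units; that floor lies within the scatter), but both are only floors, so the true steps may stay within the scatter or may turn out larger. The step between the two earlier compounds cannot be read, and most of the values shown still sit at a limit: the limit of > 50000 nM in this assay, at which 2 of the 3 values shown sit.

The compounds shown leave open how large the gap to methyl and chloro really is, since that would take a number, not a limit, for compound 1 or compound 2. They also leave open what other groups would give at this same place on the shared core, such as an amine, a carboxylic acid or a longer chain, and whether any of those would read as a number or as a limit.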